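A few compounds are considered here, and "the series" means these few. Any claim that something is new, unique, unknown or untested is made for them only; others in the source may bear on it.

In an assay on HEK293 cells for positive allosteric modulation of metabotropic glutamate receptor 2 (Rattus norvegicus), read by thallium flux, with a stated time of 2.5 min (a lower number here means that less compound is needed, a higher number that more compound is needed for the effect), the three measured compounds gave:

compound 1, `Cc1c(OCCCCOCOc2ccc(C(=O)O)cc2)ccc(C(=O)CC2CCCC2)c1O`: 228 nM
compound 2, `Cc1c(OCCCCOc2ccccc2C(=O)O)ccc(C(=O)CC2CCCC2)c1O`: 335 nM
compound 3, `COc1ccc(C(=O)O)cc1OCCCCOc1ccc(C(=O)CC2CCCC2)c(O)c1C`: 425 nM

Compound 3 carries the highest of the three numbers, yet neither step separating it from the others leaves the scatter: a 1.3-fold higher number from compound 2 to compound 3 (0.10 log units; within the scatter) and a 1.9-fold higher number from compound 1 to compound 3 (0.27 log units; within the scatter). All three compounds share the same core and differ only in the carboxy-bearing aryl piece at the far end of the chain.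

Compound 4, `Cc1ccc(C(=O)O)cc1OCCCCOc1ccc(C(=O)CC2CCCC2)c(O)c1C`, has not yet been measured. It differs from compound 3 by methyl in place of methoxy on an aromatic carbon. For the measured compounds named here, no measured step touches this exact exchange; the step of a 1.3-fold higher number from compound 2 to compound 3 (0.10 log units; within the scatter) is the only one that brings a methoxy into that aryl piece, and it, like a 1.5-fold higher number from compound 1 to compound 2 (0.17 log units; within the scatter), stays within the scatter. Since every change so far at this end of the molecule has left this assay essentially unmoved, the step of a 1.1-fold lower number from compound 3 to compound 4 (0.03 log units; within the scatter) is expected to be small. Compound 4 is therefore estimated at 400 nM, with a range from 200 nM to 800 nM.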

Compound 4, half-maximal effective concentration: 1290 nM
Beside the measured number, compound 4's estimate is 3.2-fold (0.51 log units) below it; the whole stated range lies below it.
By their numbers in this assay, from the lowest: compounds 1, 2 and 3 (each within the scatter of the next); then compound 4.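

In this assay, for the compounds shown here, the aryl piece at the far end of the chain turns out not to be indifferent: on this aromatic carbon, ortho to a large group and para to a carboxy group, methyl in place of methoxy gives a 3.0-fold higher number from compound 3 to compound 4 (0.48 log units; beyond the scatter) and so moves the number beyond the scatter, which no step among compound 1, compound 2 and compound 3 did. The 5-carboxy-2-methylphenyl end also sets compound 4 apart from the other two, with a 3.9-fold higher number from compound 2 to compound 4 (0.59 log units; beyond the scatter) and with a 5.7-fold higher number from compound 1 to compound 4 (0.75 log units; beyond the scatter) as well. Nothing available accounts for this sensitivity to so small an exchange.

From the compounds shown here alone, whether chlorine, fluorine or an ethoxy group on this carbon would read like the methoxy or like the methyl stays open. Also open, going by these compounds, is whether the exchange would have the same effect with a tetrazole in place of the carboxy group.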